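High-permeability aminoquinoline series: phenoxy to isopentyl swap

This account rests on a few compounds, and the source may have more. Where it says the series, first, only, none or still open, it means among the compounds named here.

Compound 1 `c1ccc(Oc2ccc3c(NCCCNCc4ccco4)ccnc3c2)cc1` and compound 2 `COc1cccc(CNCCCNc2ccnc3cc(Oc4ccc(Cl)cc4)ccc23)c1O` share a core and were both run in an ADME assay for permeability, using PAMPA, with a stated time of 30 min, at pH 7.4; on this read-out higher numbers stand for higher permeability and lower numbers for lower permeability. In this assay compound 1 gives 317 10^-6 cm/s and compound 2 gives 317 10^-6 cm/s, so the two stand level at the digits reported, the difference lying within the usual scatter; neither can be called the more permeable.

Compound 3 `CC(C)CCc1ccc2c(NCCCNCc3ccco3)ccnc2c1` has not yet been measured in this assay. It differs from compound 1 in one place: isopentyl in place of phenoxy on an aromatic carbon. For the measured compounds named here, no step between two measured compounds involving this kind of change is available, so the expectation rests on the shared readings of compound 1 and compound 2 alone.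

For compound 3, the expected step of a 1.1-fold lower number from compound 1 to compound 3 (0.02 log units; within the scatter) is none beyond the scatter, given that compound 1 already reads 317 10^-6 cm/s. Compound 3 is therefore estimated at 300 10^-6 cm/s, within a range of 150 10^-6 cm/s to 420 10^-6 cm/s.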

Compound 3, apparent permeability: 23 10^-6 cm/s
Compound 3: middle estimate off by 13-fold (1.12 log units), on the high side, and the stated range ends above it.
By their numbers in this assay, from the lowest: compound 3; then compounds 1 and 2 (each within the scatter of the next).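

In this assay, for the compounds shown here, isopentyl in place of phenoxy on this aromatic carbon gives a 14-fold lower number from compound 1 to compound 3 (1.14 log units; beyond the scatter) and so supplies the first step beyond the scatter. Going by these compounds alone, the read-out therefore depends on the group held at this position, which the earlier readings, with no step among them, could not show. The swap takes away the six-membered aromatic ring and the hydrogen-bond acceptor of phenoxy together, and no measurement bears on the reason for this step.

Open, as far as these compounds go, is whether a phenyl group or a pentyloxy chain on this carbon, each keeping only one of those two features, would read nearer compound 1 or nearer compound 3. Within the data shown here, also open is whether the same swap gives a step of like size when the furan-bearing side chain is replaced by the one carried by compound 2.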